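Swapping Quinoline for Isoquinoline on a Shared Core

The compounds below may be only part of what the source reports. "The series", "measured", "known", "first", "only" and "open" are said of these compounds alone.

Of the compounds shown here, three built on one shared core have been measured in an assay on Sf21 cells for inhibition of MAP kinase-interacting serine/threonine-protein kinase 1 (Homo sapiens), read by luminescence and ADP-Glo, with stated times of 10 min and 40 min, tested at 500 nM; on this read-out lower numbers stand for less inhibition and higher numbers for more inhibition at the one concentration tested (going by the name of the read-out). Compound 1 `O=C(c1ccc(-c2ccc3ncc(-c4ccc5cnccc5c4)n3c2)cc1)N1CCC(N2CCCCC2)CC1` gives 92.9%. Compound 2 `O=C(c1ccc(-c2ccc3ncc(-c4ccc5ncccc5c4)n3c2)cc1)N1CCOCC1` gives 74.7%, and compound 3 `O=C(c1ccc(-c2ccc3ncc(-c4cnc5ccccc5c4)n3c2)cc1)N1CCOCC1` gives 71%. Compound 3 thus sits at the low end of the three: its number lies within the scatter of compound 2 but beyond the scatter below compound 1. For the measured compounds named here, the one step measured so far, a number 3.7 percentage points lower from compound 2 to compound 3 (within the scatter), also exchanged one such group for another.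

Compound 4 `O=C(c1ccc(-c2ccc3ncc(-c4ccc5cnccc5c4)n3c2)cc1)N1CCOCC1` differs from compound 3 by isoquinolin-6-yl in place of quinolin-3-yl on an aromatic carbon. Compound 1 carries the same entering group but a different amide, so only its value is known, not a step. Because that single exchange, a number 3.7 percentage points lower from compound 2 to compound 3 (within the scatter), stayed within the scatter, compound 4 is expected to show a number 4 percentage points higher from compound 3 to compound 4 (within the scatter). The estimate for compound 4 is 75%, with a range from 60% to 88%.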

Compound 4, a percentage reported as inhibition, at one concentration (the size of the read-out at that concentration, not a potency): 93.7%
Estimate against measurement, compound 4: 18.7 percentage points below, and the stated range ends below it.
By their numbers in this assay, from the lowest: compounds 3 and 2 (each within the scatter of the next); then compounds 1 and 4 (each within the scatter of the next).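

On this aromatic carbon the choice of group matters: with the morpholin-4-yl amide held fixed, isoquinolin-6-yl replacing quinolin-3-yl gives a number 22.7 percentage points higher from compound 3 to compound 4 (beyond the scatter), and replacing quinolin-6-yl gives a number 19 percentage points higher from compound 2 to compound 4 (beyond the scatter). The groups have the same atom counts and differ only in how their atoms are joined, so that alone is enough to separate them in this assay. With isoquinolin-6-yl in place, the amide exchange gives a number 0.8 percentage points higher from compound 1 to compound 4 (within the scatter), so those two amides cannot be told apart here.

As far as these compounds go, whether an isoquinolin-6-yl carrying an added amine would hold this level remains open, as does whether the amide exchange would read the same with a quinolinyl group. Nothing measured here explains the gap between the groups.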